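From 3-chlorophenyl to 4-methoxyphenyl: a step in growth inhibition

The compounds below may be only part of what the source reports. "The series", "measured", "known", "first", "only" and "open" are said of these compounds alone.

Measured so far in a functional assay on HCT-116 cells (Homo sapiens) for inhibition, read by MTT assay, with a stated time of 2 days; a lower number here means a stronger inhibitor of growth, a higher number a weaker inhibitor of growth:
Compound 1 `Nc1ccccc1NC(=O)CCCNCC(=O)Nc1cccc(Cl)c1` gives 75000 nM
Compound 2 `Nc1ccccc1NC(=O)CCCNCC(=O)Nc1ccc(Cl)cc1` gives 45000 nM
Compound 3 `Nc1ccccc1NC(=O)CCCNCC(=O)Nc1cc(Cl)ccc1Cl` gives 78000 nM

Each number is the concentration needed for total growth inhibition of the cells. Compound 1 cannot be separated from the other two compounds on these numbers. The measured steps are a 1.7-fold lower number from compound 1 to compound 2 (0.22 log units; within the scatter) and a 1.0-fold higher number from compound 1 to compound 3 (0.02 log units; within the scatter), and neither stands out from the ordinary variation between repeats.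

Compound 4 `COc1ccc(NC(=O)CNCCCC(=O)Nc2ccccc2N)cc1` has not yet been measured. It differs from compound 1 by 4-methoxyphenyl in place of 3-chlorophenyl on an amide-type nitrogen. Among the compounds with values here, no measured compound here carries a methoxy group, so the evidence is only indirect. The closest guides are the other exchanges of the group on this same nitrogen, namely a 1.7-fold lower number from compound 1 to compound 2 (0.22 log units; within the scatter) and a 1.7-fold higher number from compound 2 to compound 3 (0.24 log units; within the scatter). Within the data shown here, compound 2 also matters as the one measured compound with a group named at position 4, and it gives 45000 nM in this assay. None of these exchanges moved the number beyond the scatter, so no clear shift is expected here either.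

The expected step is a 1.4-fold lower number from compound 1 to compound 4 (0.13 log units; within the scatter) in this assay. For compound 4 the estimated value is 55000 nM in this assay. For compound 4 the expected range runs from 25000 nM to 120000 nM.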

Compound 4, concentration for total growth inhibition: 44000 nM
Compound 4: middle estimate off by 1.3-fold (0.10 log units), on the high side, within the range that was stated.
By their numbers in this assay, from the lowest: compounds 4, 2, 1 and 3 (each within the scatter of the next).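

Within the data shown here, compound 4 places an oxygen-bearing group on this amide-type nitrogen for the first time, a 4-methoxyphenyl with one hydrogen-bond acceptor where 3-chlorophenyl has none, yet this assay shows a 1.7-fold lower number from compound 1 to compound 4 (0.23 log units; within the scatter) and a 1.8-fold lower number from compound 3 to compound 4 (0.25 log units; within the scatter) as the result of that exchange. The tightest comparison changes only methoxy for chloro on an aromatic carbon, taking 4-chlorophenyl to 4-methoxyphenyl, and a 1.0-fold lower number from compound 2 to compound 4 (0.01 log units; within the scatter) leaves those two compounds indistinguishable. Across all four compounds, then, neither chloro nor methoxy on this aromatic ring separates one reading from another, so the change to an oxygen-bearing group adds a new kind of substituent without a step beyond the scatter.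

Still open, as far as these compounds go, is whether an amine or a carboxylic acid on this aromatic ring, or a longer chain in the shared core, would move the number beyond the scatter, since every group compared here is a substituted phenyl on the same chain. No measurement shown gives a reason for these closely matched readings.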